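Amine variation at the chain carbon: piperidinyl replacing branched amines

This account rests on a few compounds, and the source may have more. Where it says the series, first, only, none or still open, it means among the compounds named here.

Measured compounds:
compound 1 `CCCCN(C)Cc1c(C(F)(F)F)nc2n(-c3c(C)cc(C)cc3C)c(Cl)cn12` — 310 nM
compound 2 `CCCN(Cc1c(C(F)(F)F)nc2n(-c3c(C)cc(C)cc3C)c(Cl)cn12)CC1CCC1` — 5.3 nM
compound 3 `CCN(CCC1CC1)Cc1c(C(F)(F)F)nc2n(-c3c(C)cc(C)cc3C)c(Cl)cn12` — 13 nM

All three share one core and differ only in the amine on a saturated chain carbon bound to an aromatic carbon. In an assay on cells for displacement of a labelled ligand from corticotropin-releasing factor receptor 1 (Homo sapiens), with a stated time of 100 min (on this read-out lower numbers stand for stronger inhibition and higher numbers for weaker inhibition), compound 3 gives 13 nM, the second highest of the three numbers; its nearest neighbour is compound 2, a 2.5-fold higher number from compound 2 to compound 3 (0.39 log units; beyond the scatter), and its furthest is compound 1, a 24-fold lower number from compound 1 to compound 3 (1.38 log units; beyond the scatter).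

Compound 4 `Cc1cc(C)c(-n2c(Cl)cn3c(CN4CCCCC4)c(C(F)(F)F)nc23)c(C)c1` is not yet measured. Its change from compound 3: piperidin-1-yl in place of (2-cyclopropylethyl)(ethyl)amino on a saturated chain carbon bound to an aromatic carbon. The measured steps at this place are a 58-fold lower number from compound 1 to compound 2 (1.77 log units; beyond the scatter), a 24-fold lower number from compound 1 to compound 3 (1.38 log units; beyond the scatter) and a 2.5-fold higher number from compound 2 to compound 3 (0.39 log units; beyond the scatter); the two large ones both run from the butyl(methyl)amino of compound 1 toward amines carrying a small carbocycle, and the entering piperidin-1-yl carries no such ring and two heavy atoms fewer. For the measured compounds named here, no measured pair maps directly onto this change, so the direction is uncertain. A modest rise in this assay is expected for compound 4, about a 3.8-fold higher number from compound 3 to compound 4 (0.59 log units; beyond the scatter). Compound 4 is therefore estimated at 50 nM, within 12 nM to 250 nM.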

Compound 4, inhibition constant: 1200 nM
Compound 4: the middle estimate sits 24-fold (1.38 log units) below what was measured; the measured number lies above the stated range.
By their numbers in this assay, from the lowest: compound 2; then compound 3; then compound 1; then compound 4.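

In this assay, piperidin-1-yl on the saturated chain carbon gives a 92-fold higher number from compound 3 to compound 4 (1.97 log units; beyond the scatter) and a 230-fold higher number from compound 2 to compound 4 (2.35 log units; beyond the scatter) against the two amines carrying a small carbocycle, so a ring in the amine does not by itself bring the low numbers of those two compounds. The open-chain butyl(methyl)amino also fares better, with a 3.9-fold higher number from compound 1 to compound 4 (0.59 log units; beyond the scatter) in the same read-out, which places piperidin-1-yl at the high end of the amines shown, a position the earlier compounds gave no sign of. Nothing available explains these steps.

Open, on these data alone, is whether the rise follows from tying the amine into a ring or from losing the carbocycle-bearing arm. Azepan-1-yl, pyrrolidin-1-yl, morpholin-4-yl and a piperidine bearing a cyclopropylmethyl group remain to be placed on this series.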